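A few compounds are considered here, and "the series" means these few. Any claim that something is new, unique, unknown or untested is made for them only; others in the source may bear on it.

Compound 3 `COc1ccc(-c2nnc(N3CCN(C(=O)CN4CCN(c5ccccc5OC)CC4)CC3)nc2-c2ccc(OC)cc2)cc1` is the starting point, and in a functional assay on MCF7 cells (Homo sapiens) for cytotoxicity, read by MTT assay, with a stated time of 24 h (a higher number here means a weaker inhibitor, a lower number a stronger inhibitor), it reaches only a limit. In this assay compound 3 gives > 821000 nM, which is a limit of the assay rather than a measured number. Compound 2 `COc1ccc(-c2nnc(N3CCN(C(=O)CN4CCN(c5ccccc5)CC4)CC3)nc2-c2ccc(OC)cc2)cc1` also stops at a limit in this assay, where compound 2 gives > 863000 nM. Compound 1 `Cc1ccc(-c2nnc(N3CCN(C(=O)CN4CCN(c5cccc(Cl)c5)CC4)CC3)nc2-c2ccc(C)cc2)cc1` does yield a number, as in this assay compound 1 gives 797000 nM. Within the data shown here, the one step that touches compound 3, a step that the two limits leave unreadable from compound 2 to compound 3, adds a methoxy group to an aromatic carbon. Both ends of this step are limits, and its size cannot be read. Compound 4 `COc1ccc(-c2nnc(N3CCN(C(=O)CN4CCN(c5ccccc5Cl)CC4)CC3)nc2-c2ccc(OC)cc2)cc1` differs from compound 3 by chloro in place of methoxy on an aromatic carbon. Among the measured compounds shown here, no measured step speaks directly to this exchange, and the only neighbouring step is unreadable, so the expected change from compound 3 to compound 4 in this assay, a step that the limit leaves unreadable from compound 3 to compound 4, is small and without a clear direction. Compound 4 is therefore estimated to give about 850000 nM, within a range from 300000 nM to 3000000 nM.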

Compound 4, half-maximal inhibitory concentration: > 814000 nM
Compound 4: no number, only a limit (the forecaster's own chance of this, stated with the estimate: 60%); the middle value lies beyond the limit too.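

In this assay compound 4 gives > 814000 nM as a limit of the assay and not a number. Its steps from compound 2 and compound 3 join limits only, and neither can be read. The compounds shown leave open how hydrogen, methoxy and chloro on this aromatic ring compare.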